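Trifluoromethyl in Place of Trifluoromethoxy on a Shared Core

The source may report more compounds than this note shows. Statements on the series, on what has been measured and on what is new or still open speak of the compounds shown alone.

Of the compounds shown here, three built on one shared core have been tested in an assay on isolated protein for inhibition of DNA topoisomerase 1 (Homo sapiens), with a stated time of 30 min, tested at 20 uM; on this read-out higher numbers stand for a stronger effect at the one concentration tested and lower numbers for a weaker effect. Compound 1 `Cc1ccc2nc(-c3cccc(OC(F)(F)F)c3)[nH]c(=O)c2c1` carries a trifluoromethoxy group on its pendant aromatic ring and in this assay gives 0%. Compound 3 `CCN(CC)c1ccc2nc(-c3ccccc3N(C)C)[nH]c(=O)c2c1`, which carries a dimethylamino group on that ring and a diethylamino group on the core, gives 0%, level with compound 1 at the digits shown; together these two are the lowest of the three numbers. Compound 2 `Cc1ccc2nc(-c3ccccc3C(F)(F)F)[nH]c(=O)c2c1`, which carries a trifluoromethyl group, gives 21.1%, a number higher than that of compound 1 by more than the usual scatter.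

Compound 4 `Cc1ccc2nc(-c3cccc(C(F)(F)F)c3)[nH]c(=O)c2c1` has not yet been measured. It differs from compound 1 in one place: trifluoromethyl in place of trifluoromethoxy on an aromatic carbon. Within the data shown here, no measured pair isolates exactly this change, so the expectation rests on the whole set: the one compound with a trifluoromethyl group, compound 2, gives 21.1%, while compound 1 gives 0%. A modest rise is expected, most likely staying within the scatter. Compound 4 is therefore estimated at 8%, with a range from 0% to 25%. That estimate corresponds to an expected step of a number 8 percentage points higher from compound 1 to compound 4 (within the scatter).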

Compound 4, a percentage reported as inhibition, at one concentration (the size of the read-out at that concentration, not a potency): 4.2%
The estimate for compound 4 lay 3.8 percentage points above the measured number, and the stated range covers the measured number.
By their numbers in this assay, from the lowest: compounds 1, 3 and 4 (each within the scatter of the next); then compound 2.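

In this assay, putting trifluoromethyl in place of trifluoromethoxy on this aromatic carbon, meta to a large group, gives a number 4.2 percentage points higher from compound 1 to compound 4 (within the scatter). Among these compounds, this is the first pair in the set that differs in only one place, so it gives the first direct reading of a single change on the shared core: losing the oxygen, and with it the one hydrogen-bond acceptor counted for the group that leaves, does not separate the two compounds on this read-out at the one concentration tested. Nothing available here explains why the step is this small.

Only these two fluorine-bearing groups are shown at this position, so it remains open whether a different kind of group there, such as an amine, a carboxylic acid or a longer alkyl chain, would shift the number beyond the scatter. Also open, going by these compounds, is how much the number of compound 2, at 21.1%, depends on where its trifluoromethyl group sits on the ring, and how much on other features of that compound.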